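Thiophene for pyridine on the shared core

The compounds below may be only part of what the source reports. "The series", "measured", "known", "first", "only" and "open" are said of these compounds alone.

The series builds on one shared core with a 4-hydroxyphenyl group, a chlorophenyl group and a third aromatic ring. In a functional assay on DU-145 cells (Homo sapiens) for cytotoxicity, read by CCK-8 assay and cell counting, with a stated time of 2 days (a higher number here means a weaker inhibitor, a lower number a stronger inhibitor), compound 1 `Oc1ccc(-c2cc(-c3ccccn3)nc(-c3ccccc3Cl)c2)cc1` gives "not determined" (no result reported) and compound 3 `Oc1cccc(-c2cc(-c3cccnc3)nc(-c3ccccc3Cl)c2)c1` gives "not determined" (no result reported), so only compound 2 carries a number. In this assay compound 2 `Oc1ccc(-c2cc(-c3cccc(Cl)c3)nc(-c3ccccn3)c2)cc1` gives 35200 nM, a weak inhibitor on this single reading; it stands alone, and no step between measured compounds can be drawn from what is shown.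

Compound 4 `Oc1ccc(-c2cc(-c3cccc(Cl)c3)nc(-c3cccs3)c2)cc1` is the next entry to be tested. It differs from compound 2 in one place: thiophen-2-yl in place of pyridin-2-yl on an aromatic carbon. Going by the values given here, with no measured pair to lean on, the expected step in this assay is none beyond the scatter, with no stated direction; the single value of compound 2 gives no reason to expect a move either way.

The estimate for compound 4 in this assay is therefore 30000 nM, within a range of 9000 nM to 100000 nM, which means an expected step of a 1.2-fold lower number from compound 2 to compound 4 (0.07 log units; within the scatter). A reading that comes back only as a limit of the assay is also plausible for compound 4, given how weak compound 2 is.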

Compound 4, half-maximal inhibitory concentration: 5740 nM
Compound 4: middle estimate off by 5.2-fold (0.72 log units), on the high side; the measured number lies below the stated range.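

Going by these compounds alone, the position on the aromatic carbon next to the ring nitrogen is not silent in this assay, where thiophen-2-yl in place of pyridin-2-yl gives a 6.1-fold lower number from compound 2 to compound 4 (0.79 log units; beyond the scatter), the first readable step and a modest one. The change swaps a six-membered aromatic ring with one nitrogen for a five-membered aromatic ring with one sulfur, while the hydrogen-bond donor and acceptor counts and the net charge stay the same, so the step appears without any difference in those counts. No measurement shown here accounts for the step, so its cause stays unassigned.

Ring size and the identity of the hetero atom change together in this single pair, so the compounds shown cannot separate them, and a furan-2-yl or thiophen-3-yl group at this position would be needed to tell them apart. On these data alone, it also stays open whether the step carries over to other arrangements of the shared core, such as those of compound 1 and compound 3, which offer no number to compare.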